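Cyclohexyl in Place of 2-Chloro-4-fluorobenzyl on the Ring Amine

This account rests on a few compounds, and the source may have more. Where it says the series, first, only, none or still open, it means among the compounds named here.

Compound 1 `Cc1ccc2c(NCc3ccc(NC(=O)C4CCN(Cc5ncc[nH]5)CC4)cc3)nc(N(C)C)nc2c1`, compound 2 `Cc1ccc2c(NCc3ccc(NC(=O)C4CCN(C(=O)OC(C)(C)C)CC4)cc3)nc(N(C)C)nc2c1` and compound 3 `Cc1ccc2c(NCc3ccc(NC(=O)C4CCN(Cc5ccc(F)cc5Cl)CC4)cc3)nc(N(C)C)nc2c1` share one core and differ only in the group on the amine nitrogen in a ring. In a functional assay on SV5A8 cells (Homo sapiens) for cytotoxicity (a higher number here means a weaker inhibitor, a lower number a stronger inhibitor), compound 1 gives > 20000 nM, which is a limit of the assay rather than a number. Compound 2 gives > 4820 nM in this assay, again a limit. Compound 3 gives > 5910 nM, also a limit, so compound 3 stands at the limit of the assay. The steps a step that the two limits leave unreadable from compound 1 to compound 2, a step that the two limits leave unreadable from compound 1 to compound 3 and a step that the two limits leave unreadable from compound 2 to compound 3 cannot be read. Compound 4 `Cc1ccc2c(NCc3ccc(NC(=O)C4CCN(C5CCCCC5)CC4)cc3)nc(N(C)C)nc2c1` carries cyclohexyl in place of 2-chloro-4-fluorobenzyl on an amine nitrogen in a ring. No readable step bears on this change, so no movement beyond the scatter is expected in this assay, and the step that the limit leaves unreadable from compound 3 to compound 4 is expected to leave compound 4 at or near the limit. Compound 4 is expected at 20000 nM, within 5000 nM to 80000 nM.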

Compound 4, half-maximal inhibitory concentration: > 8320 nM
Compound 4 was reported as a limit; the forecaster's own chance of this, stated with the estimate: 80%; the middle value lies beyond the limit too.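

In this assay compound 4 gives > 8320 nM, which is a limit. Among the compounds shown here, no step linking compound 4 with compound 1, compound 2 or compound 3 can be read. The compounds shown leave open whether the group on the ring amine nitrogen changes the result in this assay at all.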